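The source may hold more compounds than are shown below. What is called first, only, known or untested is meant among the compounds shown, and "the series" means these compounds.

Measured in a functional assay on Ramos cells (Homo sapiens) for antiproliferative activity; a higher number here means a weaker inhibitor, a lower number a stronger inhibitor:

- compound 1 `Nc1ncnc2c1c(-c1ccc(Oc3ccccc3)cc1)cn2C[C@H]1CCCN1C[C@@H](O)CO`: 13500 nM
- compound 2 `Nc1ncnc2c1c(-c1ccc(Oc3ccccc3)cc1)cn2C[C@H]1CCCN1C(CO)CO`: 15300 nM
- compound 3 `Nc1ncnc2c1c(-c1ccc(Oc3ccccc3)cc1)cn2C[C@H]1CCCN1C[C@@H]1CO1`: 8520 nM

Compound 3 cannot be separated from the other two on these numbers. Its gaps to them, a 1.6-fold lower number from compound 1 to compound 3 (0.20 log units; within the scatter) and a 1.8-fold lower number from compound 2 to compound 3 (0.25 log units; within the scatter), both lie within the scatter, so the three compounds stand together as one group.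

The next compound, compound 4 `Nc1ncnc2c1c(-c1ccc(Oc3ccccc3)cc1)cn2[C@H]1CCN(C[C@H]2CO2)C1`, keeps the shared core and changes how the side group is attached. It carries 1-((oxiran-2-yl)methyl)pyrrolidin-3-yl in place of (1-((oxiran-2-yl)methyl)pyrrolidin-2-yl)methyl on an aromatic nitrogen.

The measured steps bear on this only indirectly. All three swap the group on the amine nitrogen in the ring, and the remaining one, a 1.1-fold higher number from compound 1 to compound 2 (0.05 log units; within the scatter), is also within the scatter. None of them alters the attachment to the core, so the data hold no direct measure of this kind of change. With no measured guide to a direction, the expectation stays close to compound 3 at 8520 nM, with a wide margin on both sides.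

The estimated change is a 1.2-fold lower number from compound 3 to compound 4 (0.09 log units; within the scatter), which means no expected step beyond the scatter. The estimate for compound 4 is 7000 nM, with an expected range from 2000 nM to 20000 nM.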

Compound 4, half-maximal inhibitory concentration: > 50000 nM
Compound 4 was reported as a limit; the forecaster's own chance of this, stated with the estimate: 10%; middle value at least 7.1-fold (0.85 log units) from the limit.
By their numbers in this assay, from the lowest: compounds 3, 1 and 2 (each within the scatter of the next). At a limit, above all of these: compound 4.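

In this assay compound 4 is reported only as a limit, not as a number: the limit of > 50000 nM in this assay, at which 1 of the 4 values shown sits. Changing how the side group is attached to the aromatic nitrogen, with 1-((oxiran-2-yl)methyl)pyrrolidin-3-yl in place of (1-((oxiran-2-yl)methyl)pyrrolidin-2-yl)methyl, gives an at least 5.8-fold higher number from compound 3 to compound 4 (0.76 log units; beyond the scatter), so this attachment matters in a way the earlier swaps on the amine nitrogen in the ring, all within the scatter, did not reveal. Among the compounds shown here, the other two steps point the same way, an at least 3.2-fold higher number from compound 2 to compound 4 (0.51 log units; beyond the scatter) and an at least 3.7-fold higher number from compound 1 to compound 4 (0.56 log units; beyond the scatter), but each also changes the group on the amine nitrogen, so only the step from compound 3 isolates the attachment.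

The compounds shown leave open whether the same loss of activity would appear with a different group on the amine nitrogen of the pyrrolidin-3-yl form, such as 2,3-dihydroxypropyl, a plain methyl or an acrylamide. They also leave open whether a longer chain linking that ring to the aromatic nitrogen would bring back the level of compound 3.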